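Quinone series: ring size of the cyclic amine

This account rests on a few compounds, and the source may have more. Where it says the series, first, only, none or still open, it means among the compounds named here.

Measured compounds in a functional assay on MGC-803 cells (Homo sapiens) for inhibition, read by sulforhodamine B assay; on this read-out higher numbers stand for weaker inhibition and lower numbers for stronger inhibition:
- compound 1 `O=C1C=C(N2CCC2)C(=O)c2c1nc1n2[C@H]2OC[C@@H](O)[C@H]2OC1`: > 16000 nM
- compound 2 `O=C1C(N2CCCCC2)=CC(=O)c2c1nc1n2[C@H]2OC[C@@H](O)[C@H]2OC1`: > 4000 nM

Compound 1 stands on a limit of this assay, not a number: the limit of > 16000 nM in this assay, at which 1 of the 2 values shown sits. Compound 2 likewise stands on a limit, not a number: the limit of > 4000 nM in this assay, at which 1 of the 2 values shown sits. Neither value places either compound above or below the other; both sit outside the measured range.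

Compound 3 `O=C1C=C(N2CCCCC2)C(=O)c2c1nc1n2[C@H]2OC[C@@H](O)[C@H]2OC1` differs from compound 1 in one place: piperidin-1-yl in place of azetidin-1-yl on a double-bonded ring carbon. Compound 2 carries the same piperidin-1-yl group on the other double-bonded ring carbon of the shared core, and shows only a limit. Among the compounds with values here, no measured step between compounds exists here, so no size or direction of change can be read from the data.

The step that the limit leaves unreadable from compound 1 to compound 3 is expected to be none beyond the scatter, since both compound 1 and compound 2 give only limits. Compound 3 is therefore estimated at 25000 nM, with a range of 5000 nM to 120000 nM, most likely reported as a limit.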

Compound 3, half-maximal inhibitory concentration: > 8000 nM
Compound 3: a limit, no number; the forecaster's own chance of this, stated with the estimate: 85%; the middle value lies beyond the limit too.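

In this assay compound 1 gives > 16000 nM, which is a limit. Within the data shown here, compound 3 gives > 8000 nM, also a limit, so no step between compound 1 and compound 3 can be read. The compounds shown leave open whether piperidin-1-yl or azetidin-1-yl on the double-bonded ring carbon makes any difference to inhibition.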